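This account rests on a few compounds, and the source may have more. Where it says the series, first, only, none or still open, it means among the compounds named here.

Measured compounds:
compound 1, `C=C1CCCC(C)(C)C1CC[C@]1(C)CC[C@@H]([C@@H](C)C(=O)O)OO1` — > 10000 nM
compound 2, `C=C1CCCC(C)(C)C1CC[C@]1(C)CC[C@H]([C@@H](C)C(=O)OC)OO1` — 20600 nM
compound 3, `C=C1CCC[C@H]2[C@](C)(CC[C@]3(C)CC[C@@H]([C@@H](C)C(=O)O)OO3)[C@@H](C)CC[C@]12C` — 2370 nM

Of the compounds shown here, three have been tested in a functional assay on SK-MEL-28 cells (Homo sapiens) for inhibition; on this read-out higher numbers stand for weaker inhibition of growth and lower numbers for stronger inhibition of growth. Compound 1, `C=C1CCCC(C)(C)C1CC[C@]1(C)CC[C@@H]([C@@H](C)C(=O)O)OO1`, gives only a limit of the assay, > 10000 nM, and not a number; of the values shown, one sits at that limit, (the limit of > 10000 nM in this assay, at which 1 of the 3 values shown sits). Compound 2, `C=C1CCCC(C)(C)C1CC[C@]1(C)CC[C@H]([C@@H](C)C(=O)OC)OO1`, gives 20600 nM. Compound 3, `C=C1CCC[C@H]2[C@](C)(CC[C@]3(C)CC[C@@H]([C@@H](C)C(=O)O)OO3)[C@@H](C)CC[C@]12C`, gives 2370 nM, the lowest of the two numbers that are not limits; the gap to compound 2 lies beyond the scatter. Going by the values given here, none of these pairs differ in only one place, so no single step between measured compounds can be read.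

The step considered here leads from compound 3 to compound 4, `C=C1CCC[C@H]2[C@](C)(CC[C@]3(C)CC[C@H]([C@@H](C)C(=O)O)OO3)[C@@H](C)CC[C@]12C`. The change is the two compounds have the same atoms and bonds and differ only in configuration as drawn: 1 of 7 stereo elements differ; a stereocentre at a saturated ring carbon is drawn S in compound 3 and R in compound 4. Among the compounds with values here, there is no measured pair in this assay that isolates a change of configuration at that centre, so the size and direction of the step are open. The expected step from compound 3 to compound 4 is a 1.5-fold higher number from compound 3 to compound 4 (0.17 log units; within the scatter), no larger than a modest loss. Compound 4 is estimated at 3500 nM, within a range from 1000 nM to 15000 nM.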

Compound 4, concentration for 50% growth inhibition: 3310 nM
Beside the measured number, compound 4's estimate is 1.1-fold (0.02 log units) above it; measured number inside the range.
By their numbers in this assay, from the lowest: compounds 3 and 4 (each within the scatter of the next); then compound 2.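

In this assay, the stereocentre at the saturated ring carbon can now be read on its own: a 1.4-fold higher number from compound 3 to compound 4 (0.15 log units; within the scatter). The S and R forms of compound 3 and compound 4 therefore give values within the scatter of each other on this read-out. The earlier compounds differ in more than one place and could not show this, whereas this pair isolates that single centre: the fact that compounds 3 and 4 differ only in the configuration as drawn

As far as these compounds go, compound 3 and compound 4 both carry the carboxylic acid, so it stays open whether the two configurations also stay within the scatter with an amide or a primary alcohol in its place. From the compounds shown here alone, compound 1 gives only a limit of the assay, > 10000 nM, and the step at this centre on the core of compound 1 stays open.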